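This account rests on a few compounds, and the source may have more. Where it says the series, first, only, none or still open, it means among the compounds named here.

The shared core of compound 1 `CC1CC1C(=O)N1CCc2nc(C#Cc3ccccc3)sc2C1` is kept throughout, and the question is what happens in an assay on HEK293 cells for negative allosteric modulation of metabotropic glutamate receptor 5 (Homo sapiens), read by FLIPR, with a stated time of 1 h (a higher number here means a weaker inhibitor, a lower number a stronger inhibitor), when the group on the amine nitrogen in the ring is exchanged. In this assay compound 1 gives only a limit, > 10000 nM, and not a number. Compound 2 `Cc1cccc(C(=O)N2CCc3nc(C#Cc4ccccc4)sc3C2)n1` carries a 6-methylpyridin-2-yl in place of the 2-methylcyclopropyl on the carbonyl carbon. In this assay compound 2 also gives only a limit, > 10000 nM. The step that the two limits leave unreadable from compound 1 to compound 2 therefore cannot be read, since (the limit of > 10000 nM in this assay, at which 2 of the 2 values shown sit). Compound 3 `CC(C)S(=O)(=O)N1CCc2nc(C#Cc3ccccc3)sc2C1` differs from compound 1 as follows: isopropylsulfonyl in place of (2-methylcyclopropyl)carbonyl on an amine nitrogen in a ring. Within the data shown here, no measured step bears on this particular exchange, and the one comparison available sits wholly at the limit. Compound 3 is therefore expected to stay at or near that limit, a step that the limit leaves unreadable from compound 1 to compound 3 that is estimated rather than read from data. The estimate for compound 3 is 15000 nM, with a range from 4000 nM to 60000 nM.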

Compound 3, half-maximal inhibitory concentration: 11 nM
For compound 3 the middle estimate is 1400-fold (3.13 log units) above the measured one; the whole stated range lies above it.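

In this assay, the exchange of (2-methylcyclopropyl)carbonyl for isopropylsulfonyl on the amine nitrogen in the ring gives an at least 900-fold lower number from compound 1 to compound 3 (2.95 log units; beyond the scatter), which shows that the group at this position can decide whether the shared core gives a readable inhibitor at all. Among these compounds, compound 3 is the only one of the three compounds with a number rather than a limit: the limit of > 10000 nM in this assay, at which 2 of the 3 values shown sit. Among the compounds shown here, both groups joined through a carbonyl, 2-methylcyclopropyl and 6-methylpyridin-2-yl, remain at that limit, whereas the one sulfonyl group does not, but a single sulfonyl compound is one observation and not a pattern.

The compounds shown do not separate the contribution of the sulfonyl link from that of the isopropyl group it carries. Going by these compounds, how a methylsulfonyl or phenylsulfonyl group, or an isopropyl group joined through a carbonyl, would behave on the same nitrogen remains open.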